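Swapping a carboxy(methoxy)methyl for a 1-carboxyethyl

The source may report more compounds than this note shows. Statements on the series, on what has been measured and on what is new or still open speak of the compounds shown alone.

Three measured compounds share a core, although they carry different side chains. Within the data shown here, compound 1 `CCOc1cc2[nH]c(Cc3nn(CC(=O)O)c(=O)c4ccccc34)nc2cc1Cl` is the first; in a functional assay on CHO cells for antagonist activity at sphingosine 1-phosphate receptor 2 (Homo sapiens), read by GTPgammaS binding (a higher number here means a weaker inhibitor, a lower number a stronger inhibitor), compound 1 gives 109 nM. Compound 2 `COC(C(=O)O)c1nn(Cc2cn3cc(OCC4CC4)c(Cl)cc3n2)c2ccccc2c1=O` in this assay gives 58 nM, and compound 3 `O=C(Cc1nn(C2CCNC2)c(=O)c2ccccc12)Nc1ccc(OC(F)(F)F)c(Cl)c1` in this assay gives 42 nM. Compound 2 thus sits between the other two, with compound 3 nearest and compound 1 furthest, but all three numbers lie within the usual scatter of one another, so no order among them can be claimed.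

Compound 4 `C[C@H](C(=O)O)c1nn(Cc2cn3cc(OCC4CC4)c(Cl)cc3n2)c2ccccc2c1=O` has not yet been measured. It differs from compound 2 in one place: 1-carboxyethyl in place of carboxy(methoxy)methyl on an aromatic carbon. Among the measured compounds shown here, no measured pair shows this change, so there is nothing to set its size from. Because compound 2 gives 58 nM and the change is confined to a small side chain, the expected step is small, without a clear direction beyond the scatter. The step from compound 2 to compound 4 is expected to be a 1.2-fold lower number from compound 2 to compound 4 (0.06 log units; within the scatter). Compound 4 is accordingly estimated at 50 nM, with a range from 15 nM to 160 nM.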

Compound 4, half-maximal inhibitory concentration: 16 nM
Compound 4: middle estimate off by 3.1-fold (0.49 log units), on the high side; the range from low to high includes it.
By their numbers in this assay, from the lowest: compound 4; then compounds 3, 2 and 1 (each within the scatter of the next, the first and the last beyond it).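

Among these compounds, this position, on an aromatic carbon next to the ring nitrogen, proves sensitive to a small edit: in this assay, 1-carboxyethyl in place of carboxy(methoxy)methyl gives a 3.6-fold lower number from compound 2 to compound 4 (0.56 log units; beyond the scatter), and this is the first single-place step in the set. The two groups differ in the methoxy oxygen, a hydrogen-bond acceptor, and in the defined stereocentre of compound 4, and this one pair cannot separate those two differences. No measurement at hand accounts for the step.

On these data alone, what a plain carboxymethyl, the mirror-image form of 1-carboxyethyl or a longer chain such as 1-carboxypropyl would give at this position stays open. Also open, as far as these compounds go, is whether replacing the carboxylic acid with an amide would keep the lower number seen with compound 4.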